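Chalcone-pyrazole series: removing one methoxy on the ketone aryl

A few compounds are considered here, and "the series" means these few. Any claim that something is new, unique, unknown or untested is made for them only; others in the source may bear on it.

Measured so far:
- compound 1, `COc1cc(-c2cc(/C=C/C(=O)c3ccc(N)cc3)[nH]n2)cc(OC)c1OC`: 8400 nM
- compound 2, `COc1ccc(C(=O)/C=C/c2cc(-c3cc(OC)c(OC)c(OC)c3)n[nH]2)cc1OC`: 5750 nM

Both numbers come from a functional assay on ACHN cells (Homo sapiens) for inhibition, read by sulforhodamine B assay, with a stated time of 48 h; on this read-out higher numbers stand for lower toxicity in this test and lower numbers for higher toxicity in this test. Among the compounds with values here, compound 2 holds the lowest of the two numbers, with compound 1 as its only neighbour; the step of a 1.5-fold lower number from compound 1 to compound 2 (0.16 log units; within the scatter) is the single measured step and lies within the scatter, so the two compounds are not separable on this read-out.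

The unmeasured compound 3, `COc1ccc(C(=O)/C=C/c2cc(-c3cc(OC)c(OC)c(OC)c3)n[nH]2)cc1`, differs from compound 2 in one place: hydrogen in place of methoxy on an aromatic carbon. The change sits on the aryl attached to the carbonyl carbon, the same part of the molecule that was varied between compound 1 and compound 2. That variation, a whole exchange of the aryl substituent pattern, gave a 1.5-fold lower number from compound 1 to compound 2 (0.16 log units; within the scatter), which is no step beyond the scatter. Loss of a single methoxy at this position is a smaller change than that exchange, so no step beyond the scatter is expected in this assay either. The step is therefore estimated as a 1.1-fold higher number from compound 2 to compound 3 (0.05 log units; within the scatter), with the number for compound 3 expected near that of compound 2.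

For compound 3 the expected value is 6500 nM, within a range of 2500 nM to 17000 nM.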

Compound 3, concentration lethal to 50% of the cells: 6710 nM
Estimate against measurement, compound 3: 1.0-fold (0.01 log units) below, within the range that was stated.
By their numbers in this assay, from the lowest: compounds 2, 3 and 1 (each within the scatter of the next).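

Within this assay, cutting 3,4-dimethoxyphenyl back to 4-methoxyphenyl gives a 1.2-fold higher number from compound 2 to compound 3 (0.07 log units; within the scatter) and so stays inside the scatter, which means that methoxy and hydrogen at this aromatic carbon cannot be told apart on this read-out. Within the data shown here, compound 3 also links to compound 1 through a single exchange, methoxy in place of amino on an aromatic carbon, and that comparison gives a 1.3-fold lower number from compound 1 to compound 3 (0.10 log units; within the scatter) and stays inside the scatter as well, so the 4-aminophenyl, 3,4-dimethoxyphenyl and 4-methoxyphenyl versions of the aryl on the carbonyl carbon form one unresolved group in this assay where the earlier pair offered only one whole-aryl exchange. No supporting measurement is available that could explain why these three aryl groups fall so close together.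

Going by these compounds, whether an unsubstituted phenyl, with no methoxy left on this aryl, or a carboxylic acid in place of the methoxy would produce a step beyond the scatter remains open. All three compounds share the rest of the core, so the response to a change anywhere outside this aryl also remains unread.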